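This account rests on a few compounds, and the source may have more. Where it says the series, first, only, none or still open, it means among the compounds named here.

Measured so far:
compound 1, `CC(=O)c1ccc(OCC(=O)Nc2cccc(NC(=O)c3ccc(N(C)C)cc3)c2)cc1F` — 98 nM
compound 2, `CCCc1ccc(C(=O)Nc2cccc(NC(=O)COc3ccc4c(=O)ccoc4c3)c2)cc1` — 14 nM

Both numbers come from an assay on isolated protein for inhibition of Rho-associated protein kinase 2 (Homo sapiens), read by scintillation counting, radiometric assay and 33P incorporation, with a stated time of 40 min, in the presence of a further agent that is not named here; a higher number here means a weaker inhibitor, a lower number a stronger inhibitor. Of the two, compound 2 gives the lower number, and compound 1 gives a higher one, a gap beyond the usual scatter of this assay. Compound 3, `Cc1cc(C(=O)Nc2cccc(NC(=O)COc3ccc4c(=O)ccoc4c3)c2)no1`, has not yet been measured. It differs from compound 2 in one place: 5-methyl-1,2-oxazol-3-yl in place of 4-propylphenyl on a carbonyl carbon. Within the data shown here, no pair of measured compounds shows this change, so the size of the step is uncertain; compound 1 and compound 2 differ at two places at once and give no clean guide. A single change of this kind can move the number either way, and here a weakening seems the more likely outcome, so the estimate rests on an expected step of a 4.3-fold higher number from compound 2 to compound 3 (0.63 log units; beyond the scatter) from compound 2. Compound 3 is therefore expected to give about 60 nM in this assay, with a range from 15 nM to 300 nM.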

Compound 3, half-maximal inhibitory concentration: 5 nM
Beside the measured number, compound 3's estimate is 12-fold (1.08 log units) above it; the whole stated range lies above it.
By their numbers in this assay, from the lowest: compound 3; then compound 2; then compound 1.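

Putting 5-methyl-1,2-oxazol-3-yl in place of 4-propylphenyl on this carbonyl carbon gives a 2.8-fold lower number from compound 2 to compound 3 (0.45 log units; beyond the scatter) in this assay with the rest of compound 2 left unchanged. At this position, then, neither the six-membered carbon ring nor the propyl chain is needed for a low number: a five-membered aromatic ring with 2 hetero atoms and 2 hydrogen-bond acceptors, and fewer heavy atoms overall, does better here. No measurement at hand says what lies behind this step.

From the compounds shown here alone, it remains open whether the methyl group on the new ring contributes, or whether an unsubstituted 1,2-oxazol-3-yl, a 5-ethyl-1,2-oxazol-3-yl or a pyridine ring would do as well at this place. Going by these compounds, it is also open whether the same swap would lower the number on the core of compound 1.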